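Compound 4 estimate in the kinase activation assay

A few compounds are considered here, and "the series" means these few. Any claim that something is new, unique, unknown or untested is made for them only; others in the source may bear on it.

Measured compounds and values:
Compound 1 `O=C(O)c1ccc2nc(CN3CCC[C@H](O[C@H](CO)c4cc(Cl)cc(Cl)c4)[C@@H]3c3ccccc3)[nH]c2c1`: 380 nM
Compound 2 `OC[C@@H](O[C@H]1CCCN(Cc2ncc[nH]2)[C@H]1c1ccccc1)c1cc(Cl)cc(Cl)c1`: 47000 nM
Compound 3 `Cc1cc(C(=O)O)ccc1CN1CCC[C@H](O[C@H](CO)c2ccnc(Cl)c2)[C@@H]1c1ccccc1`: 50000 nM

In an assay on isolated protein for activation of cGMP-dependent protein kinase 1 (Homo sapiens), read by ADP-Glo, with stated times of 30 min and 2 h, in the presence of a further agent that is not named here (a lower number here means that less compound is needed, a higher number that more compound is needed for the effect), compound 1 gives 380 nM, the lowest of the three numbers. Compound 2 gives 47000 nM, and compound 3 gives 50000 nM, the highest of the three, though compound 3 and compound 2 lie within the scatter of one another and cannot be ordered. Within the data shown here, the one step between measured compounds that differ in a single place is a 120-fold higher number from compound 1 to compound 2 (2.09 log units; beyond the scatter); it concerns the group on the amine nitrogen in the ring, not the place changed here, so it does not bear directly on the step to compound 4.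

Compound 4 `Cc1cc(C(=O)O)ccc1CN1CCC[C@H](O[C@H](CO)c2cccc(C(F)(F)F)c2)[C@@H]1c1ccccc1` is not yet measured in this assay. It differs from compound 3 by 3-(trifluoromethyl)phenyl in place of 2-chloropyridin-4-yl on a saturated chain carbon bound to an oxygen on a saturated carbon and a saturated chain carbon. Compound 1 and compound 3 differ at this place and elsewhere, so their values show only that a carbocyclic aryl at this place can sit with a low number. Compound 4 is therefore expected to give a lower number than compound 3, with wide uncertainty: the step is estimated at a 6.3-fold lower number from compound 3 to compound 4 (0.80 log units; beyond the scatter), and compound 4 is expected at 8000 nM, within 1500 nM to 40000 nM.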

Compound 4, half-maximal effective concentration: 4100 nM
The estimate for compound 4 lay 2.0-fold (0.29 log units) above the measured number; the range from low to high includes it.
By their numbers in this assay, from the lowest: compound 1; then compound 4; then compounds 2 and 3 (each within the scatter of the next).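

In this assay, among these compounds, the place on a saturated chain carbon bound to an oxygen on a saturated carbon and a saturated chain carbon now has a direct single-place comparison, which the earlier compounds did not offer: 3-(trifluoromethyl)phenyl in place of 2-chloropyridin-4-yl gives a 12-fold lower number from compound 3 to compound 4 (1.09 log units; beyond the scatter). Among the compounds shown here, the only earlier step of this kind, a 120-fold higher number from compound 1 to compound 2 (2.09 log units; beyond the scatter), concerned the group on the amine nitrogen in the ring, so this result shows that the number also responds to the aryl group at this second place while the rest of compound 3 stays fixed. The exchange alters more than one feature at once, replacing a ring with one hetero atom by a ring of carbon only and a chlorine by trifluoromethyl, so the step cannot be assigned to either alone.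

No measurement shown here explains the size of this step. Still open, as far as these compounds go, is how the number would respond to a pyridine ring carrying trifluoromethyl or a phenyl ring carrying a single chlorine at this place, either of which would help separate the two parts of the exchange.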